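The source may report more compounds than this note shows. Statements on the series, on what has been measured and on what is new or still open speak of the compounds shown alone.

Compound 1 `CC#C[C@H]1CN(S(=O)(=O)c2ccc(N)nc2)CCN1c1ccc([C@@](O)(CO)C(F)(F)F)cc1` gives 6 nM in an assay on isolated protein for inhibition of glucokinase regulatory protein (Homo sapiens), read by AlphaScreen, with stated times of 20 min and 4 h; a higher number here means a weaker inhibitor, a lower number a stronger inhibitor. Compound 2 `CC#C[C@H]1CN(S(=O)(=O)c2ccc(N)nc2)CCN1c1ccc(S(=O)(=NC)C(F)(F)F)cc1` gives 266 nM in this assay, and compound 3 `CC#C[C@H]1CN(S(=O)(=O)c2ccc(N)nc2)CCN1c1ccc(C(O)(COC)C(F)(F)F)cc1` gives 16 nM. Compound 3 thus stands second highest of the three numbers: its nearest neighbour is compound 1, with a 2.7-fold higher number from compound 1 to compound 3 (0.43 log units; beyond the scatter), and the furthest is compound 2, with a 17-fold lower number from compound 2 to compound 3 (1.22 log units; beyond the scatter). Compound 4 `CC#CCC(O)(c1ccc(N2CCN(S(=O)(=O)c3ccc(N)nc3)C[C@@H]2C#CC)cc1)C(F)(F)F` has not yet been measured. It differs from compound 3 in one place: prop-1-yn-1-yl in place of methoxy on a saturated chain carbon, two bonds along the chain from an aromatic carbon and an oxygen on a saturated carbon. Of the measured steps, only one alters the same side group in a comparable, limited way: a 2.7-fold higher number from compound 1 to compound 3 (0.43 log units; beyond the scatter), a modest shift. The step of a 44-fold higher number from compound 1 to compound 2 (1.65 log units; beyond the scatter) exchanges the entire side group for a different kind of group and therefore says little about the present change. Within the data shown here, since the one comparable step was modest, a modest step is expected here as well, toward a higher number, as compound 4 moves a further step away from the side group of compound 1. For compound 4 the expected step is a 2.2-fold higher number from compound 3 to compound 4 (0.34 log units; beyond the scatter). Compound 4 is accordingly estimated at 35 nM, with a range from 9 nM to 140 nM.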

Compound 4, half-maximal inhibitory concentration: 5 nM
Beside the measured number, compound 4's estimate is 7.0-fold (0.85 log units) above it; the whole stated range lies above it.
By their numbers in this assay, from the lowest: compounds 4 and 1 (each within the scatter of the next); then compound 3; then compound 2.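

In this assay the exchange of methoxy for prop-1-yn-1-yl on this saturated chain carbon lowers the number (a 3.2-fold lower number from compound 3 to compound 4 (0.51 log units; beyond the scatter)), so the modest rise seen earlier on going from compound 1 to compound 3 does not mean that larger groups at this place cost binding. The earlier compounds shown here with low numbers both carried an oxygen at the end of this side chain, whereas the methoxymethyl to but-2-yn-1-yl change shows that an all-carbon end with a triple bond and no hydrogen-bond acceptor can serve as well: the hydroxymethyl-bearing compound and the new one cannot be told apart (a 1.2-fold lower number from compound 1 to compound 4 (0.08 log units; within the scatter)), and the distance from the sulfur-bearing side group of compound 2 is wide (a 53-fold lower number from compound 2 to compound 4 (1.73 log units; beyond the scatter)). Nothing available explains why this change moves the number as it does.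

Going by these compounds, whether a primary amine, a carboxylic acid, a nitrile or a chain longer than but-2-yn-1-yl would hold the number at this place remains open. Also open, on these data alone, is which configuration at the carbon bearing the oxygen matters, since compound 3 and compound 4 are drawn without one.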